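The source may report more compounds than this note shows. Statements on the series, on what has been measured and on what is new or still open speak of the compounds shown alone.

Compound 1 `O=C(NCc1cn(Cc2ccc(C(F)(F)F)cc2)nn1)c1cn(-c2ccccc2)nc1-c1ccccc1` and compound 2 `COc1ccc(Cn2cc(CNC(=O)c3cn(-c4ccccc4)nc3-c3ccccc3)nn2)cc1` share a core and differ only at one aromatic carbon: methoxy in place of trifluoromethyl on an aromatic carbon. In a functional assay on MIA PaCa-2 cells (Homo sapiens) for antiproliferative activity, read by sulforhodamine B assay, with a stated time of 48 h (a higher number here means a weaker inhibitor of growth, a lower number a stronger inhibitor of growth), compound 1 gives 17700 nM. In this assay compound 2 gives 10200 nM. The step of a 1.7-fold lower number from compound 1 to compound 2 (0.24 log units; within the scatter) is small.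

Compound 3 `COc1ccc(-c2nn(-c3ccccc3)cc2C(=O)NCc2cn(Cc3ccc(C(F)(F)F)cc3)nn2)cc1` differs from compound 1 in the core: methoxy in place of hydrogen on an aromatic carbon. For compound 3 this assay reports only a limit, > 100000 nM, which is the limit of > 100000 nM in this assay, at which 1 of the 3 values shown sits. The step of an at least 5.6-fold higher number from compound 1 to compound 3 (0.75 log units; beyond the scatter) therefore marks a clear weakening.

Compound 4 `COc1ccc(Cn2cc(CNC(=O)c3cn(-c4ccccc4)nc3-c3ccc(OC)cc3)nn2)cc1` carries the core of compound 3 and differs from it by methoxy in place of trifluoromethyl on an aromatic carbon. This is the same change as from compound 1 to compound 2, made on the other core, and the place is described in the same words. The step from compound 3 to compound 4 is expected to be about a step that the limit leaves unreadable from compound 3 to compound 4, resting on the small step seen from compound 1 to compound 2 in this assay. Compound 4 is therefore estimated at 150000 nM, with a likely range from 50000 nM to 400000 nM.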

Compound 4, concentration for 50% growth inhibition: 2500 nM
Estimate against measurement, compound 4: 60-fold (1.78 log units) above; measured number below the stated range.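

Replacing 4-(trifluoromethyl)benzyl with 4-methoxybenzyl in this assay gives an at least 40-fold lower number from compound 3 to compound 4 (1.60 log units; beyond the scatter), so this change does not carry over with the same size from one core to the other: the same change on two cores in this assay, a 1.7-fold lower number (0.24 log units; within the scatter) from compound 1 to compound 2 and an at least 40-fold lower number (1.60 log units; beyond the scatter) from compound 3 to compound 4, at least 23-fold (1.36 log units) apart, beyond the scatter of two such steps. The second change in this set of compounds also depends on its partner, since adding methoxy to the core gives a 4.1-fold lower number from compound 2 to compound 4 (0.61 log units; beyond the scatter), whereas the same addition goes the opposite way when the 4-(trifluoromethyl)benzyl group is present: the same change on two cores in this assay, an at least 5.6-fold higher number (0.75 log units; beyond the scatter) from compound 1 to compound 3 and a 4.1-fold lower number (0.61 log units; beyond the scatter) from compound 2 to compound 4, at least 23-fold (1.36 log units) apart, beyond the scatter of two such steps. Compound 3 is reported only as a limit, > 100000 nM, so the true size of these gaps is unknown, and this single set of two cores shows that the two changes interact here but gives neither a reason nor a rule for other cores.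

The compounds shown leave open whether the same interaction appears when an amine or a carboxylic acid stands in place of the methoxy on the benzyl group. They also leave open whether it survives a longer chain between the amide and the triazole.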